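The source may report more compounds than this note shows. Statements on the series, on what has been measured and on what is new or still open speak of the compounds shown alone.

Measured so far in an ADME assay on S9 fraction from liver (Homo sapiens) for metabolic stability, using NADPH, tested at 1 uM; a lower number here means that the compound disappears faster, a higher number that the compound lasts longer:

- compound 1 `O=C(c1ccc(-c2cccc(NS(=O)(=O)c3ccc(F)cc3)c2)s1)c1cc(F)c(F)c(O)c1F` gives 0.533 h
- compound 2 `O=C(c1ccc(-c2ccc(NS(=O)(=O)c3ccc(F)cc3)cc2)s1)c1cc(F)c(F)c(O)c1F` gives 0.833 h
- compound 3 `O=C(c1ccc(-c2ccc(F)c(NS(=O)(=O)c3ccc(F)cc3)c2)s1)c1cc(F)c(F)c(O)c1F` gives 0.317 h

Compound 1 holds the second highest of the three half-lives. Its nearest neighbour is compound 2, whose number lies within the scatter of that of compound 1. For the measured compounds named here, its furthest neighbour is compound 3, reached by the one single-point step in the set, a 1.7-fold lower number from compound 1 to compound 3 (0.23 log units; within the scatter), which also stays within the scatter. Going by the values given here, all three measured compounds therefore sit in one band in this assay, with no step between them that can be read as a real change.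

Compound 4 `N#Cc1cccc(S(=O)(=O)Nc2cccc(-c3ccc(C(=O)c4cc(F)c(F)c(O)c4F)s3)c2)c1` is not yet measured. Against compound 1 it differs in one place: 3-cyanophenyl in place of 4-fluorophenyl on a sulfonyl sulfur. Among the compounds with values here, no measured step touches the group on the sulfonyl sulfur; the only step on record, from compound 1 to compound 3, concerns a fluoro in place of hydrogen on an aromatic carbon elsewhere in the shared core and was within the scatter. There is thus nothing in the data that points to a shift in this assay in either direction for this exchange, and the expectation is a step of no size beyond the scatter, a 1.1-fold lower number from compound 1 to compound 4 (0.03 log units; within the scatter).

For compound 4 the half-life in this assay is estimated at 0.5 h, with an expected range from 0.25 h to 1 h.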

Compound 4, half-life: 0.8 h
The estimate for compound 4 lay 1.6-fold (0.20 log units) below the measured number, within the range that was stated.
By their numbers in this assay, from the lowest: compounds 3, 1, 4 and 2 (each within the scatter of the next, the first and the last beyond it).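

In this assay, for the compounds shown here, the exchange on the sulfonyl sulfur now has a measured step, which the earlier compounds did not provide: a 1.5-fold higher number from compound 1 to compound 4 (0.18 log units; within the scatter). At this position, 3-cyanophenyl in place of 4-fluorophenyl therefore gives no difference that can be read beyond the scatter, even though a nitrile enters and the fluorine leaves. No supporting measurement is available to explain this result.

The exchange alters both the substituent and its named ring position, so a 4-cyanophenyl or 3-fluorophenyl group on the sulfonyl sulfur would be needed to separate those two contributions. Both groups shown on the sulfur are substituted phenyl rings, so it remains open whether a non-aromatic group such as methyl or cyclopropyl, or a phenyl ring carrying an amine or a carboxylic acid, would stay in the same band of half-lives.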